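The source may report more compounds than this note shows. Statements on the series, on what has been measured and on what is new or still open speak of the compounds shown alone.

Working notes on the series.

Compound 2 `Cc1nc(N[C@@H]2C[C@H]3CC[C@@H]2C3)c2cc(-c3cccc(C(F)(F)F)c3)ccc2n1` carries trifluoromethyl on the outer ring; in an ADME assay (Rattus norvegicus) for metabolic stability (on this read-out higher numbers stand for a more stable compound and lower numbers for a less stable compound), compound 2 gives 41%. Compound 1 `Cc1nc(N[C@@H]2C[C@H]3CC[C@@H]2C3)c2cc(-c3cccc(Cl)c3)ccc2n1` differs from compound 2 by one change, (chloro in place of trifluoromethyl on an aromatic carbon), and in this assay compound 1 gives 23%. The step is a number 18 percentage points lower from compound 2 to compound 1 (beyond the scatter).

Compound 3 `FC(F)(F)c1ccc(-c2ccc3nc(Cl)nc(N[C@@H]4C[C@H]5CC[C@@H]4C5)c3c2)cc1` has a different core from compound 2; the difference between the two cores is not broken down here. In this assay compound 3 gives 84%, which stands well clear of both compound 2 and compound 1.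

Compound 4 `Clc1ccc(-c2ccc3nc(Cl)nc(N[C@@H]4C[C@H]5CC[C@@H]4C5)c3c2)cc1` has not been measured. Compared with compound 3, the change is chloro in place of trifluoromethyl on an aromatic carbon. Within the data shown here, this is the same kind of change as the one from compound 2 to compound 1, not the same: in the earlier pair the site is meta to a large group, here it is para to a large group.

The expectation for compound 4 rests on one precedent only. Since the earlier change cost compound 1 a number 18 percentage points lower from compound 2 to compound 1 (beyond the scatter), a step of similar size, a number 18 percentage points lower from compound 3 to compound 4 (beyond the scatter), is expected here, with added uncertainty from the different place and core. Compound 4 is therefore estimated at 66%, with a likely range from 50% to 82%.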

Compound 4, percent of the compound remaining: 85%
Compound 4: middle estimate off by 19 percentage points, on the low side, outside the stated range (above it).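

In this assay the new step is a number 1 percentage points higher from compound 3 to compound 4 (within the scatter) and shows that on the core of compound 3, chloro in place of trifluoromethyl makes no difference that can be told from the scatter. Set beside the earlier pair, the change does not carry over from one core to the other with a fixed size, and a step read on one of these cores cannot simply be transferred to the other: the same change on two cores in this assay, a number 18 percentage points lower (beyond the scatter) from compound 2 to compound 1 and a number 1 percentage points higher (within the scatter) from compound 3 to compound 4, 19 percentage points apart, beyond the scatter of two such steps. What this does not show is why the two steps part, as the two pairs differ both in the core and in the place of the change, which is para to a large group in compound 4, and two pairs cannot separate these or give a rule for any further core.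

The compounds shown leave open how the same change behaves when it sits at one and the same place on both cores, which would set the core apart from the place. Also open, from the compounds shown here alone, is whether other groups on the outer ring, such as a nitrile or a methoxy group, or an amine in place of the chloro on the core of compound 3, follow either step.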